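A few compounds are considered here, and "the series" means these few. Any claim that something is new, unique, unknown or untested is made for them only; others in the source may bear on it.

Among the measured compounds shown here, compound 3 `CCCC(=O)Nc1cc(Oc2ccc(Nc3nccc4[nH]cc(-c5ccc(F)cc5)c(=O)c34)cc2F)ccn1` gives 23.5% in a functional assay on HT-29 cells (Homo sapiens) for antiproliferative activity, read by MTT assay, with a stated time of 72 h, tested at 10 uM (on this read-out lower numbers stand for less inhibition and higher numbers for more inhibition at the one concentration tested (going by the name of the read-out)), the lowest of the three numbers so far. Compound 1 `CC(=O)Nc1cc(Oc2ccc(Nc3nccc4[nH]cc(-c5ccc(F)cc5)c(=O)c34)cc2F)ccn1` gives 36.8% and compound 2 `CC(C)C(=O)Nc1cc(Oc2ccc(Nc3nccc4[nH]cc(-c5ccc(F)cc5)c(=O)c34)cc2F)ccn1` gives 83.4%. The steps between them are a number 46.6 percentage points higher from compound 1 to compound 2 (beyond the scatter), a number 13.3 percentage points lower from compound 1 to compound 3 (beyond the scatter) and a number 59.9 percentage points lower from compound 2 to compound 3 (beyond the scatter), so changing only the chain on the carbonyl carbon already moves this assay by large amounts in either direction.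

Compound 4 `Nc1nccc(Oc2ccc(Nc3nccc4[nH]cc(-c5ccc(F)cc5)c(=O)c34)cc2F)c1Cl` differs from compound 3 by 2-amino-3-chloropyridin-4-yl in place of 2-((propylcarbonyl)amino)pyridin-4-yl on an oxygen on an aromatic ring. For the measured compounds named here, none of the measured steps touches this part of the molecule in the same way: each of them swaps one chain for another on the carbonyl carbon, while here the whole 2-((propylcarbonyl)amino)pyridin-4-yl is exchanged for 2-amino-3-chloropyridin-4-yl. The measured steps therefore show only that this region is sensitive, not which way this particular exchange will go. With compound 3 at the bottom of the observed numbers and the range of the three measured compounds spanning from that low value up to the high value of compound 2, a broad expectation is all that is justified.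

Compound 4 is accordingly expected to give 45%, estimated to lie between 10% and 85%. The estimated step is a number 21.5 percentage points higher from compound 3 to compound 4 (beyond the scatter).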

Compound 4, a percentage reported as inhibition, at one concentration (the size of the read-out at that concentration, not a potency): 56.2%
The estimate for compound 4 lay 11.2 percentage points below the measured number; the range from low to high includes it.
By their numbers in this assay, from the lowest: compound 3; then compound 1; then compound 4; then compound 2.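

In this assay, exchanging the amide-bearing pyridine for 2-amino-3-chloropyridin-4-yl on an oxygen on an aromatic ring does not move the number in a single direction: it gives a number 32.7 percentage points higher from compound 3 to compound 4 (beyond the scatter) and a number 19.4 percentage points higher from compound 1 to compound 4 (beyond the scatter), but a number 27.2 percentage points lower from compound 2 to compound 4 (beyond the scatter). The direction of the change therefore depends on which amide is replaced, and the 2-((isopropylcarbonyl)amino)pyridin-4-yl of compound 2 is the one group shown that goes against the rise. The earlier compounds varied only the chain on the carbonyl carbon, whereas compound 4 shows that a pyridine with no carbonyl chain at all can still give a number inside the range of the amides, although no measurement here explains why.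

The chlorine and the free amino group enter together in compound 4, so the compounds shown do not tell how much of each step belongs to either of them. Also open, as far as these compounds go, is how this assay would read for 2-aminopyridin-4-yl without the chlorine, for a fluorine in place of that chlorine, or for a cyclopropylcarbonyl amide.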